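The source may hold more compounds than are shown below. What is called first, only, known or untested is meant among the compounds shown, and "the series" means these compounds.

Measured so far in a functional assay on Jurkat cells (Homo sapiens) for antiproliferative activity, read by MTT assay; on this read-out higher numbers stand for weaker inhibition and lower numbers for stronger inhibition:
Compound 1 `COc1ccccc1/C=C1\CCc2cc(OC)c(OC)cc2C1=O` — gives only a limit of the assay, > 50000 nM.
Compound 2 `COc1cccc(/C=C2\CCc3cc(OC)c(OC)cc3C2=O)c1` — compound 2 gives 5000 nM.
Compound 3 `COc1cc2c(cc1OC)C(=O)/C(=C/c1cc(C)ccc1C)CC2` — compound 3 gives 6000 nM.

Compound 3 holds the highest of the two numbers shown; the nearest is compound 2, with a 1.2-fold higher number from compound 2 to compound 3 (0.08 log units; within the scatter), so the two are not separated. Compound 1 sits at the limit of > 50000 nM in this assay, at which 1 of the 3 values shown sits, which is a limit and not a number.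

Compound 4 `COc1cc2c(cc1OC)C(=O)/C(=C/c1cc(C)cc(C)c1)CC2` is the next step: 3,5-dimethylphenyl in place of 2,5-dimethylphenyl on a double-bonded chain carbon bound to a double-bonded ring carbon. Among the compounds with values here, two measured steps bear on it. Moving the methoxy group, an at least 10-fold lower number from compound 1 to compound 2 (1.00 log units; beyond the scatter), left the limit far behind, and replacing the 2-methoxyphenyl by the 2,5-dimethylphenyl, an at least 8.3-fold lower number from compound 1 to compound 3 (0.92 log units; beyond the scatter), did the same. Within the data shown here, no measured pair compares 2,5-dimethylphenyl with 3,5-dimethylphenyl directly, so the direction is taken from the methoxy case only. The expectation is a small lowering of the number, a 1.7-fold lower number from compound 3 to compound 4 (0.23 log units; within the scatter), possibly within the scatter. Compound 4 is therefore estimated at 3500 nM, with a range of 1200 nM to 10000 nM.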

Compound 4, half-maximal inhibitory concentration: 4000 nM
Compound 4: the middle estimate sits 1.1-fold (0.06 log units) below what was measured; low and high end bracket the measured number.
By their numbers in this assay, from the lowest: compounds 4, 2 and 3 (each within the scatter of the next). At a limit, above all of these: compound 1.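

In this assay, 3,5-dimethylphenyl in place of 2,5-dimethylphenyl gives a 1.5-fold lower number from compound 3 to compound 4 (0.18 log units; within the scatter), and 3,5-dimethylphenyl in place of 3-methoxyphenyl gives a 1.3-fold lower number from compound 2 to compound 4 (0.10 log units; within the scatter), so neither change separates compound 4 from the other two at this place. The 2-methoxyphenyl group remains the only one of the four that stands apart, with an at least 12-fold lower number from compound 1 to compound 4 (1.09 log units; beyond the scatter). The value of compound 1 is a limit of the assay and not a number: the limit of > 50000 nM in this assay, at which 1 of the 4 values shown sits.

Going by these compounds, whether any group at this place can move the number beyond the scatter from compound 2, compound 3 and compound 4 remains open. Also open, on these data alone, is how a phenyl ring carrying an amine or a carboxylic acid would behave on the shared core.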